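The compounds below may be only part of what the source reports. "The series", "measured", "known", "first", "only" and "open" are said of these compounds alone.

Compound 1 `CCCCCCCCc1ccc(OCC(=O)Cn2nnc(-c3ccccc3)n2)cc1` carries a phenyl group on its tetrazole ring, and in an assay on microsomes from brain for inhibition of Fatty-acid amide hydrolase 1 (Rattus norvegicus), read by fluorescence and HPLC, with a stated time of 60 min (on this read-out higher numbers stand for weaker inhibition and lower numbers for stronger inhibition), compound 1 gives 24 nM. Compound 2 `CCCCCCCCc1ccc(OCC(=O)Cn2nnc(C(=O)O)n2)cc1` differs only in that ring substituent, and in this assay compound 2 gives 41 nM. For the measured compounds named here, the one step between the two, a 1.7-fold higher number from compound 1 to compound 2 (0.23 log units; within the scatter), is small, so the two numbers are not told apart. Going by the values given here, compound 2 thus shows the higher of the two numbers known so far, with compound 1 as its only neighbour and within the scatter of it.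

Compound 3 `CCCCCCCCc1ccc(OCC(=O)Cn2nnnc2SC)cc1` is the next compound to be measured. It differs from compound 2 in 5-(methylsulfanyl)-1H-tetrazol-1-yl in place of 5-carboxy-2H-tetrazol-2-yl on a saturated chain carbon bound to a carbonyl carbon. Among the compounds with values here, the only measured step that bears on this change is a 1.7-fold higher number from compound 1 to compound 2 (0.23 log units; within the scatter), which replaced the substituent on the same ring and stayed within the scatter. That step does not cover the change in the point of attachment of the ring, so the expectation rests on a single weak precedent. Compound 3 is therefore expected to stay close to compound 2, with a step of a 1.0-fold lower number from compound 2 to compound 3 (0.01 log units; within the scatter) in this assay that is not expected to go beyond the scatter. The estimate for compound 3 is 40 nM, within a range from 12 nM to 130 nM.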

Compound 3, half-maximal inhibitory concentration: 22 nM
Beside the measured number, compound 3's estimate is 1.8-fold (0.26 log units) above it; the range from low to high includes it.
By their numbers in this assay, from the lowest: compounds 3, 1 and 2 (each within the scatter of the next).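

With a 1.9-fold lower number from compound 2 to compound 3 (0.27 log units; within the scatter) in this assay, the result extends what the earlier pair showed: there, only the substituent on the ring was exchanged, whereas here the point of attachment of the tetrazole changes along with its substituent, and the step still stays within the scatter. On the saturated chain carbon bound to a carbonyl carbon, 5-(methylsulfanyl)-1H-tetrazol-1-yl, which has no hydrogen-bond donor and brings in sulfur, therefore cannot be told apart from 5-carboxy-2H-tetrazol-2-yl, which has a hydrogen-bond donor and two oxygens. Nothing available explains why this exchange leaves the number within the scatter.

Because the attachment and the substituent change together in this step, the compounds shown cannot say what each contributes alone; 5-carboxy-1H-tetrazol-1-yl or 5-(methylsulfanyl)-2H-tetrazol-2-yl would separate the two. For the compounds shown here, both steps so far also lie within the scatter, so it remains open whether any group at this place, such as an amine or a longer alkyl chain on the tetrazole, would move the number beyond it.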